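A few compounds are considered here, and "the series" means these few. Any claim that something is new, unique, unknown or untested is made for them only; others in the source may bear on it.

Working notes on the series. In a functional assay for inhibition, with Homo sapiens as the target (a lower number here means a stronger inhibitor, a higher number a weaker inhibitor), compound 1 `Cc1ccc(S(=O)(=O)N[C@@H](CCC(=O)N2CCC3(CC2)CCN(c2ccncc2)CC3)C(=O)O)cc1` gives 78 nM, and compound 2 `Cc1noc(C)c1S(=O)(=O)N[C@@H](CNC(=O)N1CCC2(CC1)CCN(c1ccncc1)CC2)C(=O)O` gives 39 nM; the two numbers lie within the scatter of each other, so neither is set apart. Compound 3 `O=C(N[C@@H](CCC(=O)N1CCC2(CC1)CCN(c1ccncc1)CC2)C(=O)O)OCc1ccccc1` is not yet measured in this assay. It differs from compound 1 by benzyloxycarbonyl in place of (4-methylphenyl)sulfonyl on an amine nitrogen. Going by the values given here, no measured pair tests this change, so no step size can be read from the data. A modest weakening beyond the scatter is expected, giving a 2.1-fold higher number from compound 1 to compound 3 (0.31 log units; beyond the scatter) as the expected step. Compound 3 is therefore estimated at 160 nM in this assay, within a range of 50 nM to 500 nM.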

Compound 3, half-maximal inhibitory concentration: 4580 nM
Compound 3: middle estimate off by 29-fold (1.46 log units), on the low side; measured number above the stated range.
By their numbers in this assay, from the lowest: compounds 2 and 1 (each within the scatter of the next); then compound 3.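

In this assay, the substituent on this amine nitrogen is far from interchangeable: benzyloxycarbonyl in place of (4-methylphenyl)sulfonyl gives a 59-fold higher number from compound 1 to compound 3 (1.77 log units; beyond the scatter) on the same core. This large step arises although both groups have the same heavy-atom count and each carries one six-membered aromatic ring. Nothing available speaks to the reason for the step. Still open, as far as these compounds go, is whether a sulfonyl group is what matters here, which a methanesulfonyl or benzylsulfonyl group on this nitrogen could test. A phenylacetyl group would test whether a carbonyl-linked group without the carbamate oxygen behaves like benzyloxycarbonyl.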